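Thiophene for Methylphenyl in a Hydroxamic Acid Series

The source may report more compounds than this note shows. Statements on the series, on what has been measured and on what is new or still open speak of the compounds shown alone.

Compound 2 `Cc1ccccc1-c1nc(CNc2ccc(C(=O)NO)cc2)n(-c2ccccc2)n1` is measured in an assay on Sf9 cells for inhibition of protein deacetylase HDAC6 (Homo sapiens), read by fluorescence, with a stated time of 40 min, tested at 100 nM (on this read-out higher numbers stand for more inhibition at the one concentration tested (going by the name of the read-out) and lower numbers for less inhibition), and gives 53.2%. Among the three measured compounds it stands second highest: compound 1 `O=C(NO)c1ccc(NCc2nc(-c3ccccc3)nn2-c2cccc(Cl)c2)cc1` gives 62.3%, a number within the scatter of compound 2, while compound 3 `NNC(=O)c1ccc(NCc2nc(-c3ccccc3)nn2-c2ccccc2)cc1`, which carries a hydrazide instead of the hydroxamic acid, gives 10%, well beyond the scatter below compound 2.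

Compound 4 `Cc1ccc(-c2nc(CNc3ccc(C(=O)NO)cc3)n(-c3ccccc3)n2)s1` differs from compound 2 in one place (5-methylthiophen-2-yl in place of 2-methylphenyl on an aromatic carbon). For the measured compounds named here, no measured pair shows this change, so its size is unknown. Compound 4 is expected to stay close to compound 2, with a number 3.2 percentage points lower from compound 2 to compound 4 (within the scatter) estimated as a step of no clear direction beyond the scatter. The estimate for compound 4 in this assay is 50%, ranging from 25% to 72%.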

Compound 4, a percentage reported as inhibition, at one concentration (the size of the read-out at that concentration, not a potency): 79.7%
Estimate against measurement, compound 4: 29.7 percentage points below; the measured number lies above the stated range.
By their numbers in this assay, from the lowest: compound 3; then compounds 2 and 1 (each within the scatter of the next); then compound 4.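

The position on the aromatic carbon between two ring nitrogen atoms responds to the group it carries: in this assay, 5-methylthiophen-2-yl in place of 2-methylphenyl gives a clear gain (a number 26.5 percentage points higher from compound 2 to compound 4 (beyond the scatter)). For the compounds shown here, the earlier compounds offered no step in one place, so this is the first change here whose size can be read. Nothing available accounts for this step. The compounds shown leave open whether the step belongs to the sulfur-containing ring or to where its methyl sits. An unsubstituted thiophene or a furan at this position would help separate the two.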